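Chloro in Place of Hydrogen: Expected Stability of Compound 4

A few compounds are considered here, and "the series" means these few. Any claim that something is new, unique, unknown or untested is made for them only; others in the source may bear on it.

Measured so far in an ADME assay on microsomes from liver (Rattus norvegicus, strain Sprague-Dawley) for metabolic stability, read by LC-MS, with a stated time of 15 min, tested at 20 uM; on this read-out higher numbers stand for a more stable compound and lower numbers for a less stable compound:
compound 1, `O=C(OCc1ccccc1)c1coc(-c2ccccc2)n1`, gives 2.7%
compound 2, `O=C(Oc1c(Cl)cc(Cl)cc1Cl)c1coc(-c2ccccc2)n1`, gives 15.5%
compound 3, `O=C(Oc1ccc(Cl)cc1Cl)c1coc(-c2ccccc2)n1`, gives 17.3%

Compound 1 stands lowest of the three; compound 2 lies nearest to it and compound 3 furthest, both beyond the scatter. From compound 3 to compound 2 the change is chloro in place of hydrogen on an aromatic carbon, and the step is a number 1.8 percentage points lower from compound 3 to compound 2 (within the scatter). The difference between the core of compound 1 and the core of compound 3 is not broken down here.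

Compound 4, `O=C(OCc1ccccc1)c1coc(-c2ccccc2Cl)n1`, is not yet measured in this assay. It differs from compound 1 by chloro in place of hydrogen on an aromatic carbon. This is the same kind of change as that from compound 3 to compound 2, though there the place is also meta to two chloro groups, which it is not here. The expectation for compound 4 rests on that one measured step, a number 1.8 percentage points lower from compound 3 to compound 2 (within the scatter), which stayed within the scatter, and on the low starting point of compound 1 at 2.7%. The expected step is therefore a number 2.3 percentage points higher from compound 1 to compound 4 (within the scatter). Compound 4 is estimated to give 5%, between 1% and 15%.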

Compound 4, percent of the compound remaining: 7.9%
Beside the measured number, compound 4's estimate is 2.9 percentage points below it, within the range that was stated.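

On the core of compound 1, chloro in place of hydrogen, here phenyl to 2-chlorophenyl, gives in this assay a number 5.2 percentage points higher from compound 1 to compound 4 (within the scatter). Set beside the earlier step, the two readings show no difference that repeated measurement would not allow: the same change on two cores in this assay, a number 1.8 percentage points lower (within the scatter) from compound 3 to compound 2 and a number 5.2 percentage points higher (within the scatter) from compound 1 to compound 4, 7 percentage points apart, within the scatter of two such steps. So in these two pairs the change left the number within the scatter on either core, but two pairs do not show that this would hold on other cores or at other places on the ring, and with compound 1 at 2.7% there is little room for a lower number on this core.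

The compounds shown leave open how the number would move with a group other than chloro at this place, such as methoxy, a nitrile or an amine. They also leave open whether an amide in place of the ester would shift the number on either core.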